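Benzyl for phenyl on the ether oxygen: cytotoxicity outlook

A few compounds are considered here, and "the series" means these few. Any claim that something is new, unique, unknown or untested is made for them only; others in the source may bear on it.

compound 1 `CC(=O)Nc1cccc(-c2ccc(C(=O)N(Cc3cccc(OCCCCCC(=O)O)c3)C(C)C)cc2)c1`, in an ADME assay on HepG2 cells (Homo sapiens) for cytotoxicity, read by CellTiter-Glo and resazurin assay, with a stated time of 72 h (a lower number here means that less compound is needed, a higher number that more compound is needed for the effect), a limit of > 26000 nM
compound 2 `CC(C)COc1cccc(-c2ccc(C(=O)N(Cc3cccc(OCCCCCC(=O)O)c3)C(C)C)cc2)c1`, in this assay a limit of > 26000 nM
compound 3 `CC(C)N(Cc1cccc(OCCCCCC(=O)O)c1)C(=O)c1ccc(-c2cccc(Oc3ccccc3)c2)cc1`, in this assay a limit of > 18700 nM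

Compound 3 stands at a limit of this assay, not at a measured number. The other two compounds also sit at limits, as the limit of > 26000 nM in this assay, at which 2 of the 3 values shown sit, and the limit of > 18700 nM in this assay, at which 1 of the 3 values shown sits, show, so none of the three is ordered against another. The steps from compound 1 to compound 2, a step that the two limits leave unreadable from compound 1 to compound 2, from compound 1 to compound 3, a step that the two limits leave unreadable from compound 1 to compound 3, and from compound 2 to compound 3, a step that the two limits leave unreadable from compound 2 to compound 3, are all left unreadable by the limits.

Compound 4 `CC(C)N(Cc1cccc(OCCCCCC(=O)O)c1)C(=O)c1ccc(-c2cccc(OCc3ccccc3)c2)cc1` differs from compound 3 by benzyl in place of phenyl on an oxygen on an aromatic ring. The step that bears most directly on it is a step that the two limits leave unreadable from compound 2 to compound 3, which also swaps the group on that oxygen, yet its size cannot be read. With every shown value at a limit, the account expects no readable change, and the step from compound 3 to compound 4 is estimated as a step that the limit leaves unreadable from compound 3 to compound 4. Compound 4 is therefore expected near 30000 nM, within 10000 nM to 100000 nM, most likely again reported only as a limit.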

Compound 4, half-maximal effective concentration: > 26000 nM
Compound 4 ended at the assay's limit; the forecaster's own chance of this, stated with the estimate: 85%; the middle value is on the limit's open side.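

In this assay compound 4 gives > 26000 nM as a limit and not a number. No step among compound 1, compound 2, compound 3 and compound 4 can be read: the limit of > 26000 nM in this assay, at which 3 of the 4 values shown sit.

The compounds shown leave open at what concentration any of them reaches the half-maximal effect in this assay and whether the group on the oxygen changes that concentration at all.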